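The compounds below may be only part of what the source reports. "The series", "measured", "known", "first", "only" and "open" are said of these compounds alone.

Measured compounds in a functional assay on the whole organism for inhibition, with Rattus norvegicus as the target; a lower number here means that less compound is needed, a higher number that more compound is needed for the effect:
- compound 1 `CC1CC/C(=N\Nc2cccc(Br)c2)c2ncc(C(=O)O)c(=O)n21`: 0.4 umol/kg
- compound 2 `CC1CC/C(=N\Nc2ccc(Br)cc2)c2ncc(C(=O)O)c(=O)n21`: 0.8 umol/kg
- compound 3 `CC1CC/C(=N\Nc2ccccc2O)c2ncc(C(=O)O)c(=O)n21`: 0.26 umol/kg

Compound 2 stands at the highest number of the three in this assay. Its nearest neighbour is compound 1, the step being a 2.0-fold higher number from compound 1 to compound 2 (0.30 log units; within the scatter). Its furthest neighbour is compound 3, the step being a 3.1-fold lower number from compound 2 to compound 3 (0.49 log units; beyond the scatter). Between the other two the step is a 1.5-fold lower number from compound 1 to compound 3 (0.19 log units; within the scatter).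

Compound 4 `CC(C)c1ccc(N/N=C2\CCC(C)n3c2ncc(C(=O)O)c3=O)cc1` has not yet been measured in this assay. It differs from compound 2 in one place: isopropyl in place of bromo on an aromatic carbon. Among the compounds with values here, all three measured steps also alter the group on the amine nitrogen, so they are the ones that bear on this change, but none of them exchanges bromo for isopropyl; the closest in kind, a shift of the bromo on the same ring, is a 2.0-fold higher number from compound 1 to compound 2 (0.30 log units; within the scatter), which stays within the scatter, and the only step beyond the scatter, a 3.1-fold lower number from compound 2 to compound 3 (0.49 log units; beyond the scatter), is modest. On that basis no step beyond the scatter is expected for compound 4 in this assay, in either direction, though the data give no direct guide for an isopropyl group. The expected step is no change at the digits printed from compound 2 to compound 4 (within the scatter). Compound 4 is therefore estimated at 0.8 umol/kg, with a range from 0.3 umol/kg to 2 umol/kg.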

Compound 4, dose for 50% inhibition: 2.4 umol/kg
Compound 4: middle estimate off by 3.0-fold (0.48 log units), on the low side, and the stated range ends below it.
By their numbers in this assay, from the lowest: compounds 3, 1 and 2 (each within the scatter of the next, the first and the last beyond it); then compound 4.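

In this assay, within the data shown here, isopropyl in place of bromo on the aromatic carbon para to a large group gives a 3.0-fold higher number from compound 2 to compound 4 (0.48 log units; beyond the scatter), the first step that changes only the group on this carbon and lies beyond the scatter. The earlier compounds shown here showed only that moving the bromo around the ring, from compound 1 to compound 2, stays within the scatter; this result shows that the identity of the group at the para carbon can also shift the dose. The exchange replaces one bromine with three carbons and leaves the counts of hydrogen-bond donors, hydrogen-bond acceptors and net charge unchanged, and no measurement is available to account for the step.

Compounds with a methyl, a methoxy, an amine or a carboxylic acid at this para carbon are absent from those shown, so one exchange cannot establish a trend across groups there. Also open, as far as these compounds go, is whether isopropyl in the place of the bromo of compound 1 would give a step like that from bromo to isopropyl at the para carbon in this assay.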